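Losing the Methyl: From Compound 3 to Compound 4

The source may report more compounds than this note shows. Statements on the series, on what has been measured and on what is new or still open speak of the compounds shown alone.

Measured so far in an assay on Sf21 cells for inhibition of cytochrome c oxidase subunit 2 (Homo sapiens), read by spectrophotometry, with a stated time of 5 min; on this read-out lower numbers stand for stronger inhibition and higher numbers for weaker inhibition:
- compound 1 `NS(=O)(=O)c1ccc(N2C(=O)CC(C3CCCCC3=O)C2=O)cc1`: 21300 nM
- compound 2 `COc1ccc(C(=O)CC2CC(=O)N(c3ccc(S(N)(=O)=O)cc3)C2=O)cc1`: 2100 nM
- compound 3 `Cc1ccc(C(=O)CC2CC(=O)N(c3ccc(S(N)(=O)=O)cc3)C2=O)cc1`: 980 nM

Compound 3 gives the lowest number of the three. Its nearest neighbour is compound 2, a modest step apart a 2.1-fold lower number from compound 2 to compound 3 (0.33 log units; beyond the scatter), and compound 1 sits far behind both. All three share the same core; compound 1 carries a saturated ring with a ketone in place of the aryl ketone found in compounds 2 and 3.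

The next compound, compound 4 `NS(=O)(=O)c1ccc(N2C(=O)CC(CC(=O)c3ccccc3)C2=O)cc1`, is compound 3 with one change: hydrogen in place of methyl on an aromatic carbon. Among the measured compounds shown here, only one measured step bears on this change, the one from compound 2 to compound 3, where a methyl replaced a methoxy at the same position and the number fell modestly a 2.1-fold lower number from compound 2 to compound 3 (0.33 log units; beyond the scatter). That step says the group at this position matters a little, but it says nothing direct about an unsubstituted ring. With so thin a basis, the expected step from compound 3 to compound 4 in this assay is small and uncertain, leaning slightly toward a higher number a 1.5-fold higher number from compound 3 to compound 4 (0.18 log units; within the scatter). Compound 4 is therefore estimated at 1500 nM, with a range from 600 nM to 4000 nM.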

Compound 4, half-maximal inhibitory concentration: 4230 nM
For compound 4 the middle estimate is 2.8-fold (0.45 log units) below the measured one, outside the stated range (above it).
By their numbers in this assay, from the lowest: compound 3; then compounds 2 and 4 (each within the scatter of the next); then compound 1.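

In this assay, compound 4 shows this ring with nothing on that aromatic carbon, and taking the methyl away gives a 4.3-fold higher number from compound 3 to compound 4 (0.64 log units; beyond the scatter), so the 4-methylphenyl group gives a lower number than plain phenyl. Hydrogen and methoxy, by contrast, are not separated, with a 2.0-fold higher number from compound 2 to compound 4 (0.30 log units; within the scatter), which means that putting just any group at this place does not lower the number: among these three groups, only methyl stands apart from the other two. No independent measurement is available to explain why methyl differs from hydrogen and methoxy here.

With only three groups compared at this one carbon, the compounds shown leave open whether the gain is particular to methyl or would also appear with an ethyl group, a chlorine atom or a trifluoromethyl group in its place. They also leave open how an amine or a carboxylic acid at the same carbon would read in this assay, and whether the methyl would give a similar step on a compound with a different core.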